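The source may hold more compounds than are shown below. What is called first, only, known or untested is meant among the compounds shown, and "the series" means these compounds.

Measured compounds:
compound 1, `Cc1cc(NC(=O)Cn2nnc(-c3ccccc3)n2)n(C(C)C)n1`: 107%
compound 2, `O=C(Cn1nnc(-c2ccccc2)n1)Nc1cc(C2(C(F)(F)F)CC2)nn1C1CCCCC1`: "not active" (no number reported)

Going by the values given here, compound 1, `Cc1cc(NC(=O)Cn2nnc(-c3ccccc3)n2)n(C(C)C)n1`, is the one compound here with a number: in an assay on HEK293 cells for activation of Kir3.1/Kir3.2 (Homo sapiens), read by thallium flux (on this read-out higher numbers stand for larger maximal responses and lower numbers for smaller maximal responses), compound 1 gives 107%. Compound 2, `O=C(Cn1nnc(-c2ccccc2)n1)Nc1cc(C2(C(F)(F)F)CC2)nn1C1CCCCC1`, is the only other entry, and in this assay compound 2 is recorded as "not active" (no number reported), with no number attached to it. Among the compounds with values here, no two measured compounds differ in a single place, so no measured step is known, and the two entries together say only that one compound reached a large maximal response and the other was reported as not active.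

Compound 3, `Cc1cc(NC(=O)Cn2nnc(-c3ccccc3)n2)n(Cc2ccccc2)n1`, has not yet been measured. It differs from compound 1 in one place: benzyl in place of isopropyl on an aromatic nitrogen. The benzyl that enters is a larger group than the isopropyl that leaves and brings a six-membered aromatic ring of carbon only.

With a single number in hand, the expected step from compound 1 to compound 3 in this assay is uncertain in direction; the estimate is a moderate downward step, a number 22 percentage points lower from compound 1 to compound 3 (beyond the scatter), reaching somewhat beyond the usual scatter. Compound 3 is therefore expected to give about 85%, within a range from 40% to 115%.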

Compound 3, largest response reached (Emax), in percent of the reference or control that the assay uses: 74%
The estimate for compound 3 lay 11 percentage points above the measured number, within the range that was stated.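

The aromatic nitrogen that carries isopropyl in compound 1 is a place where a change shows up clearly in this assay: benzyl in place of isopropyl gives a number 33 percentage points lower from compound 1 to compound 3 (beyond the scatter), a large step beyond the usual scatter. The change does not abolish the response, however, since compound 3 still gives 74%, so this nitrogen accepts a larger group with a six-membered aromatic ring while keeping measurable activation. No measurement here explains why the response falls, so the step stands only as an observation.

This single step cannot separate the effect of the added carbon atoms from that of the aromatic ring, and a saturated ring such as cyclopentyl or a longer chain such as n-butyl on the same nitrogen would be needed to tell them apart. As far as these compounds go, compound 2 differs from compound 1 in more than one place, so its "not active" record cannot be tied to the group on this nitrogen, and it remains open how an amine or a carboxylic acid at this position would behave.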